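This account rests on a few compounds, and the source may have more. Where it says the series, first, only, none or still open, it means among the compounds named here.

Measured in an ADME assay on HaCaT cells (Homo sapiens) for cytotoxicity, read by MTT assay, with a stated time of 72 h; on this read-out higher numbers stand for weaker inhibition and lower numbers for stronger inhibition:
compound 1 `Cc1cc(-c2ccccc2)n(/C(N)=N/S(=O)(=O)c2cc(C)c(Cl)cc2SCc2cccc3ccccc23)n1` gives 12000 nM;
compound 2 `Cc1cc(-c2ccccc2)n(/C(N)=N/S(=O)(=O)c2cc(C)c(Cl)cc2SCc2ccc(C(F)(F)F)cc2)n1` gives 18000 nM;
compound 3 `Cc1cc(S(=O)(=O)/N=C(\N)n2nccc2-c2ccccc2)c(SCc2ccc(C(F)(F)F)cc2)cc1Cl` gives 19000 nM.

Compound 4 `Cc1cc(S(=O)(=O)/N=C(\N)n2nccc2-c2ccccc2)c(SCc2cccc3ccccc23)cc1Cl` has not yet been measured in this assay. Its core is that of compound 3, and the two cores of compounds 2 and 3 differ by hydrogen in place of methyl on an aromatic carbon, a change that gave a 1.1-fold higher number from compound 2 to compound 3 (0.02 log units; within the scatter). The change from compound 3 to compound 4 is naphthalen-1-yl in place of 4-(trifluoromethyl)phenyl on a saturated chain carbon bound to a sulfur. The same change, (naphthalen-1-yl in place of 4-(trifluoromethyl)phenyl on a saturated chain carbon bound to a sulfur), has been measured once before, between compound 2 and compound 1, where it gave a 1.5-fold lower number from compound 2 to compound 1 (0.18 log units; within the scatter). On that single precedent, a step of a 1.5-fold lower number from compound 3 to compound 4 (0.16 log units; within the scatter) is expected from compound 3 to compound 4 in this assay, because the earlier step of a 1.5-fold lower number from compound 2 to compound 1 (0.18 log units; within the scatter) stayed within the scatter. The value of compound 4 in this assay is therefore estimated at 13000 nM, most likely between 6000 nM and 28000 nM.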

Compound 4, half-maximal inhibitory concentration: 11000 nM
Estimate against measurement, compound 4: 1.2-fold (0.07 log units) above; the measured number falls inside the stated range.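

In this assay, naphthalen-1-yl in place of 4-(trifluoromethyl)phenyl gave a 1.7-fold lower number from compound 3 to compound 4 (0.24 log units; within the scatter), and the step read alike on both cores: the same change on two cores in this assay, a 1.5-fold lower number (0.18 log units; within the scatter) from compound 2 to compound 1 and a 1.7-fold lower number (0.24 log units; within the scatter) from compound 3 to compound 4, 1.2-fold (0.06 log units) apart, within the scatter of two such steps. Hydrogen in place of methyl on an aromatic carbon gave a 1.1-fold lower number from compound 1 to compound 4 (0.04 log units; within the scatter), and this step also read alike on both cores: the same change on two cores in this assay, a 1.1-fold higher number (0.02 log units; within the scatter) from compound 2 to compound 3 and a 1.1-fold lower number (0.04 log units; within the scatter) from compound 1 to compound 4, 1.2-fold (0.06 log units) apart, within the scatter of two such steps. Both changes thus carried from one core to the other with no difference beyond the scatter, but since every step itself lies within the scatter, the data do not show that either change moves the number at all.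

The compounds shown leave open whether this holds for an amine or a carboxylic acid in place of these groups. They also leave open whether a step beyond the scatter would carry over in the same way.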